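A few compounds are considered here, and "the series" means these few. Any claim that something is new, unique, unknown or untested is made for them only; others in the source may bear on it.

Measured in an ADME assay on HEK-293T cells (Homo sapiens) for cytotoxicity, read by MTT assay, with a stated time of 48 h; on this read-out lower numbers stand for higher toxicity in this test and higher numbers for lower toxicity in this test:

Compound 1 `CC1(C)[C@H]2CC[C@]1(C)[C@H](OC(=O)CCCN1CCCCC1)C2` gives 74800 nM.
Compound 2 `CC1(C)[C@H]2CC[C@]1(C)[C@H](OC(=O)CCN1CCCCCC1)C2` gives 183000 nM.
Compound 3 `CC1(C)[C@H]2CC[C@]1(C)[C@H](OC(=O)CCCN1CCCCCC1)C2` gives 62200 nM.

Compound 3 has the lowest number of the three in this assay, but it cannot be separated from compound 1, since a 1.2-fold lower number from compound 1 to compound 3 (0.08 log units; within the scatter). Compound 2 stands further away, with a higher number than compound 3 that lies beyond the scatter.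

Compound 4 `CN(C)CCCC(=O)O[C@@H]1C[C@@H]2CC[C@@]1(C)C2(C)C` differs from compound 3 in one place: dimethylamino in place of azepan-1-yl on a saturated chain carbon, three bonds along the chain from a carbonyl carbon. The step that bears most directly on this change is the one at the same place on the chain, where a ring of another size replaced the ring on the amine: a 1.2-fold lower number from compound 1 to compound 3 (0.08 log units; within the scatter). The other step, a 2.4-fold higher number from compound 1 to compound 2 (0.39 log units; beyond the scatter), changed the ring and the chain length together and is less comparable. One exchange of amine at this position left the number within the scatter, so only a small step is expected in this assay, if any, with the direction uncertain.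

The expected number for compound 4 is therefore 80000 nM, in a range from 40000 nM to 160000 nM, which corresponds to an estimated 1.3-fold higher number from compound 3 to compound 4 (0.11 log units; within the scatter).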

Compound 4, half-maximal cytotoxic concentration: 101000 nM
Estimate against measurement, compound 4: 1.3-fold (0.10 log units) below; the measured number falls inside the stated range.
By their numbers in this assay, from the lowest: compounds 3, 1, 4 and 2 (each within the scatter of the next, the first and the last beyond it).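

In this assay, exchanging azepan-1-yl for dimethylamino, which has no ring and fewer heavy atoms, gives a 1.6-fold higher number from compound 3 to compound 4 (0.21 log units; within the scatter), and exchanging piperidin-1-yl for dimethylamino gives a 1.4-fold higher number from compound 1 to compound 4 (0.13 log units; within the scatter). At this place on the chain, three bonds along from a carbonyl carbon, an amine without a ring therefore cannot be told apart from the two ring amines, so neither ring is required to keep the number in this range, and the step that also alters the chain, a 1.8-fold lower number from compound 2 to compound 4 (0.26 log units; within the scatter), is likewise not separated. No measurement given here explains these numbers.

Going by these compounds, it remains open whether morpholin-4-yl or a primary amine at this place would stay within the same range. A longer chain carrying dimethylamino is also untested among the compounds shown.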